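The compounds below may be only part of what the source reports. "The series", "measured", "known", "first", "only" and "open" are said of these compounds alone.

Compound 1 `O=C1N=C(N2N=C(c3ccccc3)CC2c2ccccc2O)S/C1=C1/C(=O)Nc2ccccc21` and compound 2 `O=C1N=C(N2N=C(c3ccccc3)CC2c2ccccc2O)S/C1=C1/C(=O)Nc2ccc(Br)cc21` share a core, and compound 2 carries one change, (bromo in place of hydrogen on an aromatic carbon). In a functional assay on cells (Melanoma cell, Homo sapiens) for cytotoxicity, read by sulforhodamine B assay, with a stated time of 48 h (on this read-out higher numbers stand for weaker inhibition of growth and lower numbers for stronger inhibition of growth), compound 1 gives 4400 nM, while compound 2 gives 660 nM, so the change is a 6.7-fold lower number from compound 1 to compound 2 (0.82 log units; beyond the scatter). Compound 3 `COc1ccc(C2=NN(C3=NC(=O)/C(=C4\C(=O)Nc5ccccc54)S3)C(c3ccc(OC)cc3)C2)cc1` has a different core; the difference between the two cores is not broken down here. In this assay compound 3 gives 100000 nM, the highest number of the three measured compounds, above compound 1 and further above compound 2.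

Compound 4 `COc1ccc(C2=NN(C3=NC(=O)/C(=C4\C(=O)Nc5ccc(Br)cc54)S3)C(c3ccc(OC)cc3)C2)cc1`, not yet measured, is compound 3 with the same change, (bromo in place of hydrogen on an aromatic carbon), at the same place as in compound 2. It is expected to move in this assay by a 4.0-fold lower number from compound 3 to compound 4 (0.60 log units; beyond the scatter), a step of about the size seen in compound 2 because of a 6.7-fold lower number from compound 1 to compound 2 (0.82 log units; beyond the scatter); that the same step carries over to the other core rests on a single pair only. Compound 4 is therefore estimated at 25000 nM, with a range from 8000 nM to 100000 nM, the high end allowing for the weak starting point of compound 3.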

Compound 4, concentration for total growth inhibition: 410 nM
Beside the measured number, compound 4's estimate is 61-fold (1.79 log units) above it; the measured number lies below the stated range.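

In this assay, bromo in place of hydrogen on an aromatic carbon gives a large step on the second core, a 240-fold lower number from compound 3 to compound 4 (2.39 log units; beyond the scatter). The direction of the step is the same on both cores, but its size does not carry over from one core to the other: the same change on two cores in this assay, a 6.7-fold lower number (0.82 log units; beyond the scatter) from compound 1 to compound 2 and a 240-fold lower number (2.39 log units; beyond the scatter) from compound 3 to compound 4, 37-fold (1.56 log units) apart, beyond the scatter of two such steps This rests on two pairs only, so it shows that a step measured on one core is a poor guide to the size of the step on the other, but it gives no reason for the gap and no rule for further cores in this series.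

Still open is whether the gap follows the methoxy groups of compound 3 or the hydroxy group of compound 1, as the compounds shown change these together. Also open, as far as these compounds go, is whether chloro, a nitrile or an amine on the same aromatic carbon would give steps that differ between the two cores in the same way.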